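Swapping a halogenated phenyl ring and watching HeLa cell toxicity

The source may hold more compounds than are shown below. What is called first, only, known or untested is meant among the compounds shown, and "the series" means these compounds.

Three compounds share one core and were tested in a toxicity assay on HeLa cells (Homo sapiens) for cytotoxicity; on this read-out lower numbers stand for higher toxicity in this test and higher numbers for lower toxicity in this test. Compound 1 `COc1nc(-c2ccc(Br)cc2)ccc1[C@@H](c1ccccc1)[C@@](O)(CCN(C)C)c1cccc2ccccc12` has a 4-bromophenyl group on the pyridine-type ring of the core. In this assay compound 1 reaches only the limit of > 64 ug/mL, so no single number is known for it. Compound 3 `COc1ncc(-c2ccccc2)cc1[C@@H](c1ccccc1)[C@@](O)(CCN(C)C)c1cccc2ccccc12` carries the phenyl group at a different position of that ring and in this assay gives 30.4 ug/mL. Compound 2 `COc1ncc(-c2ccccc2)cc1[C@@H](c1ccccc1)[C@@](O)(CCN(C)C)c1cc(F)ccc1F` has no reported result in this assay, shown as "nd" (no result reported). The new compound 4 `COc1nc(-c2cccc(F)c2)ccc1[C@@H](c1ccccc1)[C@@](O)(CCN(C)C)c1cccc2ccccc12` differs from compound 1 in one place: 3-fluorophenyl in place of 4-bromophenyl on an aromatic carbon. Among the compounds with values here, no measured pair of compounds here differs in just one place, so no measured step guides this change. Because compound 1 sits at the limit of > 64 ug/mL in this assay, at which 1 of the 3 values shown sits, its own value is open-ended. The step from compound 1 to compound 4 is expected to stay within the usual scatter, with an at least 1.0-fold lower number from compound 1 to compound 4 (0.02 log units; that floor lies within the scatter) as the estimate. For compound 4 in this assay the expected value is 60 ug/mL, in a range from 30 ug/mL to 120 ug/mL, with a fair chance that only a limit is reported again.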

Compound 4, half-maximal cytotoxic concentration: 62.8 ug/mL
Estimate against measurement, compound 4: 1.0-fold (0.02 log units) below; low and high end bracket the measured number.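

In this assay, within the data shown here, compound 4 gives 62.8 ug/mL, the first single number for a substituted phenyl group at this place, next to the ring nitrogen. The entry for compound 1, > 64 ug/mL, is a limit and not a number. The change from 4-bromophenyl to 3-fluorophenyl can therefore be read only as a floor, an at least 1.0-fold lower number from compound 1 to compound 4 (0.00 log units; that floor lies within the scatter), and the true size of the step stays unknown, for this reason: the limit of > 64 ug/mL in this assay, at which 1 of the 4 values shown sits.

This swap changes two things at once, the halogen and where it sits on the phenyl ring, and the compounds shown cannot tell those two changes apart. Also open, on these data alone, is how an amine or a carboxylic acid on that phenyl ring would read in this assay.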